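Compound 2 and its butyl analogue: free fraction

The source may report more compounds than this note shows. Statements on the series, on what has been measured and on what is new or still open speak of the compounds shown alone.

In an ADME assay on the whole organism (plasma, Homo sapiens) for protein binding, read by LC-MS, with a stated time of 24 h (on this read-out higher numbers stand for a larger free fraction and lower numbers for a smaller free fraction), compound 1 (`CN(C(=O)OCc1c(-c2ccc(O[C@H]3CCC[C@H](C(=O)O)C3)cc2)nnn1C)C1CCCC1`) gives 0.033. In the same assay, compound 3 (`Cc1nc(-c2nnn(C)c2COC(=O)N(C)CC2CCC2)cnc1O[C@H]1CCC[C@H](C(=O)O)C1`) gives 0.034. Compound 2 (`Cc1noc(-c2ccc(O[C@H]3CCC[C@H](C(=O)O)C3)cn2)c1COC(=O)N(C)C1CCCC1`) stands lowest of the three at 0.004, and its gaps to the other two both lie beyond the scatter.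

Compound 4 (`CCCCN(C)C(=O)OCc1c(C)noc1-c1ccc(O[C@H]2CCC[C@H](C(=O)O)C2)cn1`) departs from compound 2 at one place: butyl in place of cyclopentyl on an amide-type nitrogen. In words, butyl replaces cyclopentyl on an amide-type nitrogen. Going by the values given here, no measured pair isolates this change, as the three measured compounds differ from one another in more than one place, so the expectation rests on compound 2 and its value of 0.004 alone.

The expectation in this assay is no step beyond the scatter, with only a slight lean towards a larger free fraction. The expected step is a 1.3-fold higher number from compound 2 to compound 4 (0.10 log units; within the scatter), and it is estimated to stay within the scatter. For compound 4 the estimate is 0.005, with an expected range of 0.002 to 0.012.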

Compound 4, unbound fraction: 0.007
Compound 4: the middle estimate sits 1.4-fold (0.15 log units) below what was measured; measured number inside the range.
By their numbers in this assay, from the lowest: compounds 2 and 4 (each within the scatter of the next); then compounds 1 and 3 (each within the scatter of the next).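

Going by these compounds alone, compound 2 and compound 4 form the first pair that differs in one place only, and in this assay butyl in place of cyclopentyl on an amide-type nitrogen gives a 1.8-fold higher number from compound 2 to compound 4 (0.24 log units; within the scatter). At this position on this core, the ring of the cyclopentyl group can therefore be given up for an open chain of butyl without a difference that can be read from the scatter, and the two compounds stand as equivalent on this read-out. Nothing measured here speaks to the reason for this result.

Open, on these data alone, is whether a longer chain such as hexyl, or an amine carried on the butyl chain, would produce a step beyond the scatter at this nitrogen. Also open, as far as these compounds go, is whether the same replacement reads alike on the core of compound 1.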